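The source may hold more compounds than are shown below. What is called first, only, known or untested is meant among the compounds shown, and "the series" means these compounds.

Compound 1, `N#Cc1c(-c2ccc(Cl)cc2)nc(SCC(=O)Nn2c(COc3ccc(Cl)cc3Cl)nc3ccccc3c2=O)[nH]c1=O`, compound 2, `N#Cc1c(-c2ccc(O)cc2)nc(SCC(=O)Nn2c(COc3ccc(Cl)cc3Cl)nc3ccccc3c2=O)[nH]c1=O`, and compound 3, `Cn1c(SCC(=O)Nn2c(COc3ccc(Cl)cc3Cl)nc3ccccc3c2=O)nc(-c2ccc(Cl)cc2)c(C#N)c1=O`, were tested in a functional assay on the whole organism (strain albino) for inhibition, with Rattus norvegicus as the target, read by paw edema, with a stated time of 1 h, at a dose of 100 mg/kg by the oral route; a lower number here means less inhibition, a higher number more inhibition at the dose given (going by the name of the read-out). Compound 1 gives 63.6%, compound 2 gives 63.6%, and compound 3 gives 76.4% in this assay.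

Compound 2 differs from compound 1 by hydroxy in place of chloro on an aromatic carbon. The step of no change at the digits printed from compound 1 to compound 2 (within the scatter) shows that this exchange left the read-out where it was. Compound 3 differs from compound 1 by methyl in place of hydrogen on an aromatic nitrogen, and the step of a number 12.8 percentage points higher from compound 1 to compound 3 (beyond the scatter) is a modest rise, making compound 3 the highest of the three, with both compound 1 and compound 2 lying beyond the scatter below it.

Compound 4, `Cn1c(SCC(=O)Nn2c(COc3ccc(Cl)cc3Cl)nc3ccccc3c2=O)nc(-c2ccc(O)cc2)c(C#N)c1=O`, has not yet been measured. It stands to compound 3 as compound 2 stands to compound 1: the change is hydroxy in place of chloro on an aromatic carbon, the same change as before, at the same place, now made on the core of compound 3 rather than on the core of compound 1.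

Because the step of no change at the digits printed from compound 1 to compound 2 (within the scatter) was flat, the same change on compound 3 is expected to leave the read-out roughly unchanged, so the step from compound 3 to compound 4 is estimated to be a number 0.4 percentage points lower from compound 3 to compound 4 (within the scatter). This rests on one pair only, so the expectation is held loosely. For compound 4 a value of 76% is expected in this assay, with a range from 63% to 86%.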

Compound 4, a percentage reported as inhibition, in the whole organism at one dose (the size of the read-out at that dose, not a potency): 80%
Compound 4: the middle estimate sits 4 percentage points below what was measured; the range from low to high includes it.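

In this assay, hydroxy in place of chloro on the core of compound 3 gives a number 3.6 percentage points higher from compound 3 to compound 4 (within the scatter) and so leaves the read-out within the scatter on both cores, as it did on the core of compound 1: the same change on two cores in this assay, no change at the digits printed (within the scatter) from compound 1 to compound 2 and a number 3.6 percentage points higher (within the scatter) from compound 3 to compound 4, 3.6 percentage points apart, within the scatter of two such steps. Methyl in place of hydrogen on the aromatic nitrogen, now on the 4-hydroxyphenyl core, gives a number 16.4 percentage points higher from compound 2 to compound 4 (beyond the scatter) and thus repeats the rise seen on the 4-chlorophenyl core, with the two rises not told apart: the same change on two cores in this assay, a number 12.8 percentage points higher (beyond the scatter) from compound 1 to compound 3 and a number 16.4 percentage points higher (beyond the scatter) from compound 2 to compound 4, 3.6 percentage points apart, within the scatter of two such steps. Within these four compounds, the two changes therefore carry from one core to the other, each seen on two cores only, but this does not show that they would carry to any other core, nor why the methyl step raises the read-out, and a single dose at a single time gives no measure of potency.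

The compounds shown leave open whether an amine or a methoxy group in place of the hydroxy on that aromatic ring would also leave the read-out within the scatter. They also leave open whether an ethyl group or a longer chain in place of the methyl on the nitrogen would keep the rise.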